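The source may report more compounds than this note shows. Statements on the series, on what has been measured and on what is new or still open speak of the compounds shown alone.

Compound 1 `NCc1cn(CC(=O)NCc2ccccc2)nn1`: > 2000 uM, a limit of the assay
Compound 2 `O=C(Cn1cc(-c2cccc([N+](=O)[O-])c2)nn1)NCc1ccccc1`: > 2000 uM, a limit of the assay
Compound 3 `COc1cc(OC)cc(-c2cn(CC(=O)NCc3ccccc3)nn2)c1`: "non-toxic" (no number reported)

In an ADME assay on cells (spleen, Mus musculus, strain C57BL/6) for inhibition, read by flow cytometry and propidium iodide staining, with a stated time of 24 h, at 37 degrees C (on this read-out higher numbers stand for an effect only at larger amounts of compound and lower numbers for an effect already at smaller amounts), compound 3 has no single number, and its entry reads "non-toxic" (no number reported). Going by the values given here, the only numerical information is the limit of > 2000 uM in this assay, at which 2 of the 3 values shown sit.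

Compound 4 `COc1cccc(-c2cn(CC(=O)NCc3ccccc3)nn2)c1` is the next structure. The structural change is hydrogen in place of methoxy on an aromatic carbon, meta to a large group.

No step beyond the usual scatter is expected in this assay. This expectation rests on compound 2, whose entry is the limit > 2000 uM.

Compound 4 is expected at 2000 uM, with an estimated range of 1000 uM to 4000 uM.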

Compound 4, concentration for half-maximal effect: 840 uM
For compound 4 the middle estimate is 2.4-fold (0.38 log units) above the measured one; the measured number lies below the stated range.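

In this assay compound 4 gives 840 uM, the only number in the series shown that is not a limit. Methoxy in place of nitro gives an at least 2.3-fold lower number from compound 2 to compound 4 (0.37 log units; beyond the scatter), and 3-methoxyphenyl in place of aminomethyl gives an at least 2.3-fold lower number from compound 1 to compound 4 (0.37 log units; beyond the scatter). Both sizes are bounds only: the limit of > 2000 uM in this assay, at which 2 of the 4 values shown sit.

The step between compound 3 and compound 4 cannot be read: compound 3 has only the entry "non-toxic". Open, on these data alone, is how a carboxylic acid, an amine or a longer alkoxy chain in place of the methoxy group would read out.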